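Bromo added to the benzyl group of compound 3

A few compounds are considered here, and "the series" means these few. Any claim that something is new, unique, unknown or untested is made for them only; others in the source may bear on it.

In a functional assay on HCT-116 cells (Homo sapiens) for antiproliferative activity, read by WST assay, with a stated time of 72 h (a higher number here means a weaker inhibitor of growth, a lower number a stronger inhibitor of growth), compound 3 (`O=C(NO)c1cnc(N2C[C@@H]3[C@H](C2)[C@H]3NCc2ccccc2)nc1`) gives the lowest of the three numbers (120 nM). Compound 1 (`O=C(NO)c1cnc(N2C[C@@H]3[C@H](C2)[C@H]3NS(=O)(=O)c2ccc3ccccc3c2)nc1`) gives a higher number (440 nM), and compound 2 (`O=C(NO)c1cnc(N2C[C@@H]3[C@H](C2)[C@H]3NC(=O)c2cccs2)nc1`) the highest (3600 nM). Compound 4 (`O=C(NO)c1cnc(N2C[C@@H]3[C@H](C2)[C@H]3NCc2ccc(Br)cc2)nc1`) has bromo in place of hydrogen on an aromatic carbon, para to a large group (bromo in place of hydrogen on an aromatic carbon). Going by the values given here, the one measured step, a 30-fold lower number from compound 2 to compound 3 (1.48 log units; beyond the scatter), is large, but it exchanges (thiophen-2-yl)carbonyl for benzyl on an amine nitrogen. Among the compounds with values here, no measured pair tests a substituent on the benzyl group, so no step beyond the scatter is expected in this assay, with wide uncertainty. The expected step is a 1.2-fold lower number from compound 3 to compound 4 (0.08 log units; within the scatter) and would lie within the scatter. Compound 4 is estimated at 100 nM (range 35 nM to 300 nM).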

Compound 4, concentration for 50% growth inhibition: 250 nM
Estimate against measurement, compound 4: 2.5-fold (0.40 log units) below; the range from low to high includes it.
By their numbers in this assay, from the lowest: compound 3; then compounds 4 and 1 (each within the scatter of the next); then compound 2.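

In this assay, the benzyl ring of this series does not accept bromo without cost: bromo in place of hydrogen, para to a large group, gives a 2.1-fold higher number from compound 3 to compound 4 (0.32 log units; beyond the scatter), a modest loss. Much of the gain of the benzyl group over (thiophen-2-yl)carbonyl on the amine nitrogen remains with 4-bromobenzyl, at a 14-fold lower number from compound 2 to compound 4 (1.16 log units; beyond the scatter). Nothing available accounts for the step from hydrogen to bromo.

As far as these compounds go, whether this loss is particular to bromo stays open. Fluoro, methoxy, an amine or a carboxylic acid could be tested at the same place. Their values would show whether other substituents there give a similar step.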